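Replacing 4-methylphenyl with pyridin-3-yl on compound 1

The source may report more compounds than this note shows. Statements on the series, on what has been measured and on what is new or still open speak of the compounds shown alone.

compound 1 `Cc1ccc(Oc2cccc(CN3CCC(n4cc(C)c(=O)[nH]c4=O)CC3)c2)cc1`: > 64000 nM
compound 2 `Cc1cn(C2CCN(Cc3cncc(Oc4cc(Cl)cc(Cl)c4)c3)CC2)c(=O)[nH]c1=O`: > 64000 nM

In an ADME assay on MRC5 cells (Homo sapiens) for cytotoxicity, read by fluorescence and resazurin assay, with a stated time of 3 days (on this read-out lower numbers stand for stronger inhibition and higher numbers for weaker inhibition), compound 1 gives > 64000 nM. That entry is a limit of the assay and not a number. Compound 2 also gives a limit, > 64000 nM. The measurements so far therefore show only (the limit of > 64000 nM in this assay, at which 2 of the 2 values shown sit).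

Compound 3 `Cc1cn(C2CCN(Cc3cccc(Oc4cccnc4)c3)CC2)c(=O)[nH]c1=O` keeps the core of compound 1 but carries pyridin-3-yl in place of 4-methylphenyl on an oxygen on an aromatic ring. Among the measured compounds shown here, no measured pair shows what this exchange does on its own. The expected step of a number no higher from compound 1 to compound 3 (the limit leaves the size open) is none beyond the usual scatter, an expectation that rests on compound 1 and its limit of > 64000 nM. Compound 3 may well return only a limit too. For compound 3 the estimate is 64000 nM, with an expected range of 30000 nM to 100000 nM.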

Compound 3, half-maximal inhibitory concentration: > 64000 nM
Compound 3 ended at the assay's limit; the forecaster's own chance of this, stated with the estimate: 80%; the middle value lies on the limit itself.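

Compound 1 and compound 3 both end at a limit of this assay and not at a number, so no step between them can be read: the limit of > 64000 nM in this assay, at which 3 of the 3 values shown sit.

The compounds shown leave open how far past that limit each one lies, and so whether pyridin-3-yl in place of 4-methylphenyl changes the read-out at all.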